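Growth inhibition after swapping the aryl group on the ring nitrogen

A few compounds are considered here, and "the series" means these few. Any claim that something is new, unique, unknown or untested is made for them only; others in the source may bear on it.

Compound 1 `CN1CCN(CCCOc2cccc3nc(Nc4ccc(F)c(F)c4)ccc23)CC1` gives 700 nM in a functional assay on UACC-62 cells (Homo sapiens) for inhibition, read by sulforhodamine B assay, with a stated time of 48 h; a lower number here means a stronger inhibitor of growth, a higher number a weaker inhibitor of growth.
Compound 2 `CN1CCN(CCCOc2cccc3nc(Nc4cccc(Cl)c4)ccc23)CC1` gives 1910 nM in this assay.

Among the two numbers measured so far, compound 1 stands lowest, with compound 2 as its nearest neighbour at a 2.7-fold higher number from compound 1 to compound 2 (0.44 log units; beyond the scatter). That single step is the only one recorded, and it changes the same position that is changed on the way to compound 3 `CN1CCN(CCCOc2cccc3nc(Nc4ccc(Cl)c(C(F)(F)F)c4)ccc23)CC1`, which is still to be measured in this assay. The change from compound 1 to compound 3 is 4-chloro-3-(trifluoromethyl)phenyl in place of 3,4-difluorophenyl on a nitrogen on an aromatic ring. Among the measured compounds shown here, the one measured step at this position, a 2.7-fold higher number from compound 1 to compound 2 (0.44 log units; beyond the scatter), shows that replacing the 3,4-difluorophenyl moved the number upward by a modest amount, so a modest rise is the more likely outcome here as well, though the new group differs from the 3-chlorophenyl of compound 2 and nothing in the data fixes its direction with confidence. Compound 3 is therefore expected to show a 1.6-fold higher number from compound 1 to compound 3 (0.20 log units; within the scatter), a small weakening relative to compound 1 that may not clear the usual scatter. The estimate for compound 3 is 1100 nM, with a range from 350 nM to 3500 nM.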

Compound 3, concentration for 50% growth inhibition: 1720 nM
Compound 3: middle estimate off by 1.6-fold (0.19 log units), on the low side, within the range that was stated.
By their numbers in this assay, from the lowest: compound 1; then compounds 3 and 2 (each within the scatter of the next).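

In this assay, a second replacement of the 3,4-difluorophenyl on this nitrogen moves the number the same way as the first (a 2.5-fold higher number from compound 1 to compound 3 (0.39 log units; beyond the scatter)), so compound 1 remains the strongest inhibitor of growth among the three compounds, and neither replacement matches it. The 4-chloro-3-(trifluoromethyl)phenyl carries 11 heavy atoms against 8 for the 3,4-difluorophenyl and adds a trifluoromethyl group, yet it cannot be separated from the 3-chlorophenyl (a 1.1-fold lower number from compound 2 to compound 3 (0.05 log units; within the scatter)), so the two chlorine-bearing aryl groups read alike at this position. Nothing available accounts for why the 3,4-difluorophenyl stands apart from these two groups.

The three compounds leave open whether the difference follows from the fluorine atoms themselves, since all three aryl groups carry halogens and no unsubstituted phenyl, single fluorine or methoxy group appears among them for comparison. They also leave open how a more different group on this nitrogen, such as an amine or a carboxylic acid on the phenyl ring, would fare in this assay against the value of compound 1 at 700 nM.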